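From methoxy to allyloxy on the shared core

The source may hold more compounds than are shown below. What is called first, only, known or untested is meant among the compounds shown, and "the series" means these compounds.

In a functional assay on MCF7 cells (Homo sapiens) for inhibition, read by radiometric assay and XTT assay (a lower number here means a stronger inhibitor, a higher number a weaker inhibitor), compound 1 (`CCCCCC[C@@]1(C)SC(O)=CC1=O`) reports only a limit of > 80 ug/mL and no number. Compound 2 (`CCCCCC[C@@]1(C)SC(=O)C=C1OC`) gives 9.4 ug/mL in this assay and compound 3 (`CCCCCCCC[C@@]1(C)SC(=O)C=C1OC`) gives 16.4 ug/mL there, so compound 3 stands level with compound 2 within the scatter. Compound 4 (`C=CCOC1=CC(=O)S[C@]1(C)CCCCCCCC`) has not yet been measured. It differs from compound 3 by a single change (vinyl in place of hydrogen on a saturated chain carbon bound to an oxygen on an unsaturated carbon): vinyl in place of hydrogen on a saturated chain carbon bound to an oxygen on an unsaturated carbon, which turns methoxy to allyloxy. Among the measured compounds shown here, the one measured step that bears on this, a 1.7-fold higher number from compound 2 to compound 3 (0.24 log units; within the scatter) on the chain, stays small, although it sits at another place. For the measured compounds named here, no measured step alters the methoxy group itself, so this guide is only indirect. The estimated change is a 1.1-fold lower number from compound 3 to compound 4 (0.04 log units; within the scatter) and no step beyond the scatter is expected in this assay for this replacement. For compound 4 the expected value is 15 ug/mL with an estimated range from 6 ug/mL to 40 ug/mL in this measurement.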

Compound 4, half-maximal inhibitory concentration: 14.5 ug/mL
Compound 4: middle estimate off by 1.0-fold (0.01 log units), on the high side, and the stated range covers the measured number.
By their numbers in this assay, from the lowest: compounds 2, 4 and 3 (each within the scatter of the next). At a limit, above all of these: compound 1.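

In this assay the replacement of methoxy by allyloxy gives a 1.1-fold lower number from compound 3 to compound 4 (0.05 log units; within the scatter), so this change at the oxygen on the shared core moves the number no further than the scatter. Among the compounds shown here, no earlier step touched this place, since the only measured step lay on the chain, and the pair now gives a direct reading: vinyl in place of hydrogen on a saturated chain carbon bound to an oxygen on an unsaturated carbon leaves compound 4 level with compound 3. Nothing in the data on hand gives a reason for this result.

Open, from the compounds shown here alone, is whether larger or different groups on that oxygen, such as benzyl or a chain ending in an amine, would also stay within the scatter. Also open, going by these compounds, is whether allyloxy reads the same on the shorter chain of compound 2.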